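This account rests on a few compounds, and the source may have more. Where it says the series, first, only, none or still open, it means among the compounds named here.

In a functional assay on SGC-7901 cells (Homo sapiens) for antiproliferative activity, read by sulforhodamine B assay, with a stated time of 72 h (a lower number here means a stronger inhibitor, a higher number a weaker inhibitor), compound 1 `CN(C)C(=S)N/N=C/c1ccc2ccccc2n1` gives 30 nM. Compound 3 `NC(=S)N/N=C/c1ccc2ccccc2n1` gives 32700 nM, the higher of the two numbers recorded, and its nearest neighbour is compound 1, reached through a 1100-fold higher number from compound 1 to compound 3 (3.04 log units; beyond the scatter). Compound 2 `NC(=S)N/N=C/c1cc2ccccc2s1` returns only a limit, > 100000 nM. Compound 4 `Fc1cccc(NC(=S)N/N=C/c2ccc3ccccc3n2)c1` differs from compound 3 by 3-fluorophenyl in place of hydrogen on an amide-type nitrogen. Among the measured compounds shown here, the one measured step that touches this position is a 1100-fold higher number from compound 1 to compound 3 (3.04 log units; beyond the scatter), a large one, showing that what sits on the amide-type nitrogen moves the number far. Compound 4 adds a 3-fluorophenyl there rather than stripping the nitrogen bare, so a lower number beyond the scatter is expected, with the size uncertain because 3-fluorophenyl is not dimethylamino. Compound 4 is therefore estimated at 1500 nM, within 150 nM to 15000 nM. The step expected is a 22-fold lower number from compound 3 to compound 4 (1.34 log units; beyond the scatter).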

Compound 4, half-maximal inhibitory concentration: 79900 nM
Compound 4: the middle estimate sits 53-fold (1.73 log units) below what was measured; the measured number lies above the stated range.
By their numbers in this assay, from the lowest: compound 1; then compound 3; then compound 4. At a limit, above all of these: compound 2.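

In this assay, a 3-fluorophenyl on the amide-type nitrogen does not restore the strength that goes with the dimethylamino group, since the change gives a 2.4-fold higher number from compound 3 to compound 4 (0.39 log units; beyond the scatter) and moves the number modestly upward. The large step, a 1100-fold higher number from compound 1 to compound 3 (3.04 log units; beyond the scatter), therefore does not extend to every group that replaces hydrogen at this nitrogen: 3-fluorophenyl and dimethylamino differ sharply here.

On these data alone, whether a single methyl, an unsubstituted phenyl or a morpholine ring at this place would give a number nearer that of compound 1 stays open. Nothing shown here explains why 3-fluorophenyl and dimethylamino part ways.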